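Adding a methyl to the chloro-bearing ring: clearance unchanged?

The source may hold more compounds than are shown below. What is called first, only, known or untested is meant among the compounds shown, and "the series" means these compounds.

Of the compounds shown here, three sharing one core have been tested in an in vitro ADME assay on microsomes from liver (Mus musculus) for pharmacokinetics, read by LC-MS, with a stated time of 10 min, tested at 1 uM; on this read-out lower numbers stand for slow clearance and higher numbers for fast clearance. Compound 1 `Cc1ccc(NC(=O)[C@H]2CN(C)C[C@@H]2c2ccc(/C=C/C(=O)Nc3ccccc3N)cc2)cc1` gives 62 mL/min/kg in this assay. Compound 2 `CN1C[C@H](C(=O)Nc2ccc(C3CC3)cc2)[C@@H](c2ccc(/C=C/C(=O)Nc3ccccc3N)cc2)C1` gives 60 mL/min/kg, and compound 3 `CN1C[C@H](C(=O)Nc2cccc(Cl)c2)[C@@H](c2ccc(/C=C/C(=O)Nc3ccccc3N)cc2)C1` gives 58 mL/min/kg. Compound 3 therefore sits at the low end of the three numbers, yet the gap to either neighbour is too small to count: the step of a 1.1-fold lower number from compound 1 to compound 3 (0.03 log units; within the scatter) and the step of a 1.0-fold lower number from compound 2 to compound 3 (0.01 log units; within the scatter) both stay inside the spread expected from repeating a measurement.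

Compound 4 `Cc1cc(NC(=O)[C@H]2CN(C)C[C@@H]2c2ccc(/C=C/C(=O)Nc3ccccc3N)cc2)ccc1Cl` has not yet been measured. It differs from compound 3 in one place: 4-chloro-3-methylphenyl in place of 3-chlorophenyl on an amide-type nitrogen.

Which steps bear on this? Swapping one ring on the amide-type nitrogen for another left the number essentially unchanged, as shown by a 1.1-fold lower number from compound 1 to compound 3 (0.03 log units; within the scatter) and a 1.0-fold lower number from compound 2 to compound 3 (0.01 log units; within the scatter). Growing a small group on such a ring, as in a 1.0-fold lower number from compound 1 to compound 2 (0.01 log units; within the scatter), also did nothing beyond the scatter. Within the data shown here, nothing among the measured compounds suggests that a further small change on this ring would move clearance.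

On that basis the step of a 1.0-fold higher number from compound 3 to compound 4 (0.01 log units; within the scatter) is expected to be nil beyond the scatter. Compound 4 is estimated at 60 mL/min/kg, within a range from 38 mL/min/kg to 95 mL/min/kg.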

Compound 4, clearance: 65 mL/min/kg
Compound 4: the middle estimate sits 1.1-fold (0.03 log units) below what was measured, within the range that was stated.
By their numbers in this assay, from the lowest: compounds 3, 2, 1 and 4 (each within the scatter of the next).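

In this assay, the change from 3-chlorophenyl to 4-chloro-3-methylphenyl on the amide-type nitrogen gives a 1.1-fold higher number from compound 3 to compound 4 (0.05 log units; within the scatter), so this is the first case shown in which the ring carries two groups, chlorine and methyl together, and the clearance number still stays inside the scatter. The other two comparisons agree, with a 1.1-fold higher number from compound 2 to compound 4 (0.03 log units; within the scatter) and a 1.0-fold higher number from compound 1 to compound 4 (0.02 log units; within the scatter), which means that the four rings shown at this position, 4-methylphenyl, 4-cyclopropylphenyl, 3-chlorophenyl and 4-chloro-3-methylphenyl, cannot be told apart on this read-out. Across these four compounds, then, small carbon or chlorine groups on this ring give no measurable handle on clearance, and the result adds a combined pattern of two groups to the single groups seen earlier.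

No measurement shown here explains this flat result or says which part of the molecule sets the clearance. As far as these compounds go, all four groups are rings of carbon only with no hydrogen-bond donors or acceptors, so it stays open whether a ring bearing an amine or a carboxylic acid at this position would shift the number beyond the scatter.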